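Chloro for nitro in the shared core: cytotoxicity notes

A few compounds are considered here, and "the series" means these few. Any claim that something is new, unique, unknown or untested is made for them only; others in the source may bear on it.

Two members of the series have so far been run in an ADME assay on HEL cells (Homo sapiens) for cytotoxicity; on this read-out lower numbers stand for higher toxicity in this test and higher numbers for lower toxicity in this test. Compound 1 `O=C(COc1cccc2ccccc12)N/N=C/c1ccccc1[N+](=O)[O-]` gives 100 ug/mL and stands at the higher of the two numbers measured. Compound 2 `COc1ccc(/C=N/NC(=O)COc2cccc3ccccc23)cc1OC` gives 52.6 ug/mL in this assay, and the gap between the two readings lies within the scatter of repeated measurements, so neither compound can be called less or more toxic than the other on present evidence. For the measured compounds named here, no pair of measured compounds differing in a single place exists in this set, so no measured step is available to guide the next change.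

Compound 3 `O=C(COc1cccc2ccccc12)N/N=C/c1ccccc1Cl` is the next candidate for this assay. Compared with compound 1 the change is: chloro in place of nitro on an aromatic carbon. Going by the values given here, no measured pair shows what this change does to the read-out, so the expectation rests on compound 1 alone, whose reading of 100 ug/mL is the only anchor. A step of a 1.3-fold lower number from compound 1 to compound 3 (0.10 log units; within the scatter) is expected, which is within the usual scatter and carries no firm direction. Compound 3 is accordingly estimated at 80 ug/mL, with a range from 35 ug/mL to 160 ug/mL.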

Compound 3, half-maximal cytotoxic concentration: 62.7 ug/mL
Estimate against measurement, compound 3: 1.3-fold (0.11 log units) above; the measured number falls inside the stated range.
By their numbers in this assay, from the lowest: compounds 2, 3 and 1 (each within the scatter of the next).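

For the compounds shown here, this is the first single-place step: in this assay, chloro in place of nitro on an aromatic carbon of a six-membered aromatic ring of carbon only, ortho to a large group, gives a 1.6-fold lower number from compound 1 to compound 3 (0.20 log units; within the scatter). At this position, a group of 3 heavy atoms with 2 hydrogen-bond acceptors and a group of 1 heavy atom with no hydrogen-bond acceptors therefore give readings that this read-out cannot separate, so the nitro is not shown to be needed for the reading of compound 1. No measurement at hand speaks to the cause of this result.

A single step at a single position leaves open whether other groups on this carbon, such as an amine, a carboxylic acid or a longer chain, would also stay within the scatter of compound 1 or would move beyond it. Also open, on these data alone, is whether chloro on another carbon of this ring would give a reading within the scatter of compound 3.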